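Removing the 3-(dimethylamino)propyl group from compound 1

The source may hold more compounds than are shown below. What is called first, only, known or untested is meant among the compounds shown, and "the series" means these compounds.

compound 1 `COc1ccc(Cc2nc(-c3cc(Br)c(OCCCN(C)C)c(Br)c3)cnc2Cl)cc1Br`: 87300 nM
compound 2 `COc1ccc(Cc2nc(-c3cc(Br)c(O)c(Br)c3)c[nH]c2=O)cc1Br`: 125000 nM

Among the compounds with values here, both values come from a functional assay on THP-1 cells (Homo sapiens) for inhibition, read by MTT assay, with a stated time of 24 h (on this read-out higher numbers stand for weaker inhibition and lower numbers for stronger inhibition), and lie within the usual scatter of each other, so compound 1 stands level with the only other measured compound. Compound 3 `COc1ccc(Cc2nc(-c3cc(Br)c(O)c(Br)c3)cnc2Cl)cc1Br` has hydrogen in place of 3-(dimethylamino)propyl on an oxygen on an aromatic ring and is still to be measured. Within the data shown here, no measured pair differs in one place only, so the data offer no direct guide. No change beyond the scatter is expected in this assay for this replacement. The estimated size of the change is a 1.1-fold higher number from compound 1 to compound 3 (0.06 log units; within the scatter) and no clear direction is expected. The estimate for compound 3 is an expected 100000 nM (range 40000 nM to 250000 nM).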

Compound 3, half-maximal inhibitory concentration: 108000 nM
Compound 3: middle estimate off by 1.1-fold (0.03 log units), on the low side; measured number inside the range.
By their numbers in this assay, from the lowest: compounds 1, 3 and 2 (each within the scatter of the next).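

In this assay, within the data shown here, the replacement of 3-(dimethylamino)propyl by hydrogen on the oxygen on the aromatic ring gives a 1.2-fold higher number from compound 1 to compound 3 (0.09 log units; within the scatter) and thus provides the first direct reading of this position. The whole 3-(dimethylamino)propoxy group can give way to hydroxy without a change beyond the scatter on this read-out. Nothing available explains this result.

The compounds shown leave open whether any other group on this oxygen would move the number beyond the scatter. A methyl group, a carboxylic acid or a longer amine chain could each test this.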